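The source may hold more compounds than are shown below. What is called first, only, known or untested is meant among the compounds shown, and "the series" means these compounds.

Measured in a functional assay on HT-29 cells (Homo sapiens) for cytotoxicity; a higher number here means that more compound is needed for the effect, a lower number that less compound is needed:
- compound 1 `COc1cc(/C=C\c2ccc(C(C)(C)C)cc2)cc(OC)c1OC`: 8.8 uM
- compound 2 `COC(=O)/C(=C/c1cccc(OC)c1)c1cc(OC)c(OC)c(OC)c1`: 7 uM
- compound 3 `COc1cc(/C=C/c2ccc(C(C)(C)C)cc2)cc(OC)c1OC`: > 25 uM (a limit of the assay, not a number)

Compound 1 at 8.8 uM and compound 2 at 7 uM lie within the scatter of each other. Compound 3 gives > 25 uM, which is a limit. The next compound to be tested in this assay is compound 4 `COc1cc(/C=C\c2ccc(SC)cc2)cc(OC)c1OC`, which keeps the Z double bond of compound 1 and carries methylsulfanyl in place of tert-butyl on an aromatic carbon.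

Going by the values given here, only one measured step is available, an at least 2.8-fold higher number from compound 1 to compound 3 (0.45 log units; beyond the scatter). It rests on (the limit of > 25 uM in this assay, at which 1 of the 3 values shown sits), and it comes with the fact that compounds 1 and 3 differ only in the configuration as drawn. That step favours the Z form that compound 4 retains, but it does not touch the group being exchanged, so it gives no direct measure of this change. The size of the new step is therefore a judgement. A step towards a lower number is expected, though the range is kept wide enough to include the value of compound 1 at 8.8 uM.

The expected result is a 4.4-fold lower number from compound 1 to compound 4 (0.64 log units; beyond the scatter). For compound 4 the estimated value is 2 uM, with an expected range from 0.2 uM to 15 uM.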

Compound 4, concentration for half-maximal effect: 1.8 uM
For compound 4 the middle estimate is 1.1-fold (0.05 log units) above the measured one, within the range that was stated.
By their numbers in this assay, from the lowest: compound 4; then compounds 2 and 1 (each within the scatter of the next). At a limit, above all of these: compound 3.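

Going by these compounds alone, until compound 4, the only step that could be read in this assay concerned the configuration of the double bond, and the group on the aromatic carbon had stayed tert-butyl throughout. With the Z double bond kept, methylsulfanyl in place of tert-butyl gives a 4.9-fold lower number from compound 1 to compound 4 (0.69 log units; beyond the scatter) and so shows that the group at this place affects the number and that tert-butyl is not required there for cytotoxicity in these cells. The facts at hand concern only the configuration of the double bond, so nothing shown bears on which feature of methylsulfanyl lies behind this step.

The compounds shown leave open whether an ethylsulfanyl chain, a methoxy group or a dimethylamino group at this place would give a number like that of compound 4, and thus whether the sulfur itself matters or merely the smaller group. It also remains open whether the step carries over to the E double bond, where the only compound shown, compound 3, gives a limit and still carries tert-butyl.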